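The source may report more compounds than this note shows. Statements on the series, on what has been measured and on what is new or still open speak of the compounds shown alone.

Measured so far in an assay on CHO cells for antagonist activity at transient receptor potential cation channel subfamily V member 1 (Homo sapiens), read by FLIPR; a higher number here means a weaker inhibitor, a lower number a stronger inhibitor:
compound 1 `CC(C(=O)NCc1ccc(C(F)(F)F)cc1N1CCCCCCC1)c1ccc(NS(C)(=O)=O)c(F)c1` – 2.8 nM
compound 2 `CC(C(=O)NCc1ccc(C(F)(F)F)cc1OC1CCCC1)c1ccc(NS(C)(=O)=O)c(F)c1` – 0.6 nM

Within the data shown here, compound 2 holds the lower of the two numbers; the only step to it, a 4.7-fold lower number from compound 1 to compound 2 (0.67 log units; beyond the scatter), is modest and beyond the scatter, so the group on this aromatic carbon does matter.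

Compound 3 `CC(C(=O)NCc1ccc(C(F)(F)F)cc1SC1CCCC1)c1ccc(NS(C)(=O)=O)c(F)c1` differs from compound 2 by cyclopentylsulfanyl in place of cyclopentyloxy on an aromatic carbon. Among the measured compounds shown here, no measured step exchanges oxygen for sulfur here; the single step at this position, a 4.7-fold lower number from compound 1 to compound 2 (0.67 log units; beyond the scatter), concerns ring size and linking atom together and cannot be read across. With the ring kept, the step is expected to be small, a 1.7-fold higher number from compound 2 to compound 3 (0.22 log units; within the scatter), likely within the scatter. Compound 3 is therefore estimated at 1 nM, with a range from 0.3 nM to 3.5 nM.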

Compound 3, inhibition constant: 0.3 nM
Estimate against measurement, compound 3: 3.3-fold (0.52 log units) above, and the stated range covers the measured number.
By their numbers in this assay, from the lowest: compounds 3 and 2 (each within the scatter of the next); then compound 1.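

In this assay, sulfur and oxygen as the atom linking the cyclopentyl group to the aromatic carbon cannot be told apart (a 2.0-fold lower number from compound 2 to compound 3 (0.30 log units; within the scatter)). Cyclopentylsulfanyl, like cyclopentyloxy, stands clear of the eight-membered nitrogen ring of compound 1 (a 9.3-fold lower number from compound 1 to compound 3 (0.97 log units; beyond the scatter)). No measurement available here explains these numbers.

Whether ring size or linking atom accounts for the gap to compound 1 remains open, since both differ in that comparison. A cyclopentylamino group at this position would separate the two.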